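The source may hold more compounds than are shown below. What is called first, only, known or untested is meant among the compounds shown, and "the series" means these compounds.

For the measured compounds named here, in a functional assay on MDA-MB-231 cells (Homo sapiens) for inhibition, read by MTT assay, with a stated time of 48 h (a higher number here means a weaker inhibitor of growth, a lower number a stronger inhibitor of growth), compound 3 `Fc1ccc(NC(=S)Nc2ccc3ncnc(Nc4cccc(Br)c4)c3c2)cc1Cl` gives 300 nM, the lowest of the two numbers known here, while compound 1 `S=C(NCc1ccccc1)Nc1ccc2ncnc(Nc3ccc(-c4ccccc4)cc3)c2c1` gives 8400 nM, a gap beyond the scatter. Compound 2 `Oc1cccc(Nc2ncnc3ccc(NC(=S)NCc4ccccc4)cc23)c1` reaches only a limit in this assay, > 30000 nM. Compound 4 `S=C(NCc1ccc(Cl)cc1)Nc1ccc2ncnc(Nc3cccc(Br)c3)c2c1` has not been measured; it differs from compound 3 in one place: 4-chlorobenzyl in place of 3-chloro-4-fluorophenyl on an amide-type nitrogen. Going by the values given here, compounds 1 and 2, which each carry a benzyl group on the same amide-type nitrogen, show the two weaker results, but both also differ from compound 3 elsewhere, so no step between measured compounds isolates this change. Compound 4 is nonetheless expected to give a higher number, a step of an 8.3-fold higher number from compound 3 to compound 4 (0.92 log units; beyond the scatter) beyond the scatter. The estimate for compound 4 is 2500 nM, between 500 nM and 12000 nM.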

Compound 4, concentration for 50% growth inhibition: 23000 nM
Compound 4: the middle estimate sits 9.2-fold (0.96 log units) below what was measured, outside the stated range (above it).
By their numbers in this assay, from the lowest: compound 3; then compound 1; then compound 4. At a limit, above all of these: compound 2.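

In this assay, exchanging the group on this amide-type nitrogen with the rest of the molecule unchanged gives a large step: a 77-fold higher number from compound 3 to compound 4 (1.88 log units; beyond the scatter). This position is therefore far from indifferent, although 3-chloro-4-fluorophenyl and 4-chlorobenzyl have the same number of heavy atoms. Compound 4 still reads as a number, whereas compound 2 stands at a limit: the limit of > 30000 nM in this assay, at which 1 of the 4 values shown sits.

On these data alone, whether the step follows the benzyl link or the changed halogens stays open, as both changed together. As far as these compounds go, how 3-chloro-4-fluorobenzyl, unsubstituted phenyl or a longer chain such as phenethyl would read here also remains open.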